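Aryl replacement from compound 2 to compound 3

This account rests on a few compounds, and the source may have more. Where it says the series, first, only, none or still open, it means among the compounds named here.

Among the compounds with values here, compound 2 `O=c1cc(-c2cccs2)oc2ccc(OCCCCCCN3CCC(O)CC3)cc12` gives 119 nM in an assay on isolated protein (Cavia porcellus) with Sigma non-opioid intracellular receptor 1 (Homo sapiens) as the target, read by radioligand binding (a higher number here means a weaker inhibitor, a lower number a stronger inhibitor), the higher of the two numbers so far; compound 1 `O=c1cc(-c2ccccc2)oc2ccc(OCCCCCCN3CCCC(O)C3)cc12` gives 86 nM in this assay, a gap within the usual scatter, so no order between them is claimed. Compound 3 `COc1ccc(-c2cc(=O)c3cc(OCCCCCCN4CCC(O)CC4)ccc3o2)cc1` differs from compound 2 by 4-methoxyphenyl in place of thiophen-2-yl on an aromatic carbon. Within the data shown here, no measured pair isolates this change. A step beyond the scatter in this assay is not expected in either direction. Compound 3 is expected to give 100 nM, with a range from 40 nM to 250 nM. The expected step is a 1.2-fold lower number from compound 2 to compound 3 (0.08 log units; within the scatter), within the scatter.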

Compound 3, half-maximal inhibitory concentration: 254 nM
For compound 3 the middle estimate is 2.5-fold (0.40 log units) below the measured one, and the stated range ends below it.
By their numbers in this assay, from the lowest: compounds 1 and 2 (each within the scatter of the next); then compound 3.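

On the aromatic carbon next to the ring oxygen, 4-methoxyphenyl in place of thiophen-2-yl gives a 2.1-fold higher number from compound 2 to compound 3 (0.33 log units; beyond the scatter) in this assay. Within the data shown here, this is the first single-place change, and it shows that this position is sensitive to the aryl group, though the step is modest. No available evidence bears on the origin of this step.

The compounds shown do not separate the contribution of the methoxy group from that of the six-membered ring. On these data alone, how a 4-chlorophenyl or pyridin-3-yl group would read at this position remains open.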